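Benzamide fluoro step in a cell growth-inhibition series

The source may report more compounds than this note shows. Statements on the series, on what has been measured and on what is new or still open speak of the compounds shown alone.

Measured so far:
compound 1 `COc1cccc(-c2nn(-c3ccccc3)cc2-c2ccnc(NCCNC(=O)Nc3cccc(C(F)(F)F)c3)c2)c1`: 15700 nM
compound 2 `O=C(NCCCNc1cc(-c2cn(-c3ccccc3)nc2-c2cccc(O)c2)ccn1)c1ccccc1`: 15200 nM

In a functional assay on PC-3 cells (Homo sapiens) for inhibition (on this read-out lower numbers stand for stronger inhibition of growth and higher numbers for weaker inhibition of growth), compound 1 gives 15700 nM; in this assay compound 2 gives 15200 nM. The two numbers lie within the usual scatter of each other, so no order between compound 1 and compound 2 can be read, and both sit at weak inhibition.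

Compound 3 `O=C(NCCCNc1cc(-c2cn(-c3ccccc3)nc2-c2cccc(O)c2)ccn1)c1ccc(F)cc1` differs from compound 2 by fluoro in place of hydrogen on an aromatic carbon, in words: fluoro in place of hydrogen on an aromatic carbon. Among the compounds with values here, no measured pair shows this kind of change, so there is no step to lean on. The expectation is a step from compound 2 to compound 3 of a 1.1-fold lower number from compound 2 to compound 3 (0.04 log units; within the scatter), that is, no change beyond the scatter. Compound 3 is therefore estimated at 14000 nM, with a range from 5000 nM to 40000 nM.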

Compound 3, concentration for total growth inhibition: 5240 nM
Compound 3: middle estimate off by 2.7-fold (0.43 log units), on the high side; the range from low to high includes it.
By their numbers in this assay, from the lowest: compound 3; then compounds 2 and 1 (each within the scatter of the next).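

In this assay, the step from phenyl to 4-fluorophenyl gives a 2.9-fold lower number from compound 2 to compound 3 (0.46 log units; beyond the scatter) and so shows that this carbon of the benzamide ring, para to a large group, responds to a single heavy atom, if only modestly. The earlier compounds shown here could not show this, as they differ in more than one place. Nothing at hand gives a measured reason for the step.

On these data alone, whether chloro, methoxy or an amine at this carbon would move the number further remains open. So does whether fluoro would give a similar step on the 3-(trifluoromethyl)phenyl urea of compound 1.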